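The source may hold more compounds than are shown below. What is called first, only, known or untested is meant among the compounds shown, and "the series" means these compounds.

Working notes on the series. In a functional assay on FM3A cells (Mus musculus) for antiproliferative activity, with a stated time of 48 h (on this read-out lower numbers stand for stronger inhibition and higher numbers for weaker inhibition), compound 1 (`C=C(Br)C(=O)Nc1ccc(/C=C/C(=O)c2ccc(F)cc2)cc1`) gives 1200 nM and compound 2 (`C=C(Br)C(=O)Nc1ccc(/C=C/C(=O)c2ccc(Cl)c(Cl)c2)cc1`) gives 3200 nM, so compound 2 holds the higher of the two numbers and the weaker inhibition. The next compound is compound 3 (`C=C(Br)C(=O)Nc1ccc(/C=C/C(=O)c2cccc(OC)c2)cc1`), which differs from compound 2 in one place: 3-methoxyphenyl in place of 3,4-dichlorophenyl on a carbonyl carbon. That is 3-methoxyphenyl in place of 3,4-dichlorophenyl on a carbonyl carbon. Going by the values given here, only one measured step bears on this change, the modest 2.7-fold higher number from compound 1 to compound 2 (0.43 log units; beyond the scatter), which brought in the same 3,4-dichlorophenyl that now leaves. Among the compounds with values here, no measured compound carries 3-methoxyphenyl, so the expectation rests on that single step. A modest move towards a lower number is expected in this assay. The estimated change is a 2.0-fold lower number from compound 2 to compound 3 (0.30 log units; within the scatter). For compound 3 the estimate is 1600 nM, with an expected range of 600 nM to 4200 nM.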

Compound 3, half-maximal inhibitory concentration: 2700 nM
The estimate for compound 3 lay 1.7-fold (0.23 log units) below the measured number, and the stated range covers the measured number.
By their numbers in this assay, from the lowest: compound 1; then compounds 3 and 2 (each within the scatter of the next).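

In this assay the change on a carbonyl carbon gives a 1.2-fold lower number from compound 2 to compound 3 (0.07 log units; within the scatter) and so does not separate 3-methoxyphenyl from 3,4-dichlorophenyl, even though chlorine leaves and oxygen enters. Against 4-fluorophenyl the same new group gives a 2.3-fold higher number from compound 1 to compound 3 (0.35 log units; beyond the scatter) so compound 1 now stands apart from both other compounds, with its steps to each beyond the scatter. A second group thus joins 3,4-dichlorophenyl on the weaker side of 4-fluorophenyl, a statement that holds for these three compounds only.

As far as these compounds go, whether 4-fluorophenyl stands out in its own right or the other two groups both lose ground stays open; an unsubstituted phenyl or an amine-bearing phenyl would set that reference. Nothing at hand gives a reason for these steps.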